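A few compounds are considered here, and "the series" means these few. Any claim that something is new, unique, unknown or untested is made for them only; others in the source may bear on it.

Compound 1, `Cc1ccc(S(=O)(=O)N2C=CNC(=O)[C@H]2CC(=O)N[C@@H]2CCCc3cc(CN4CCCCC4)ccc32)cc1`, gives 0.045 nM in an in vitro assay on cells for displacement of a labelled ligand from B1 bradykinin receptor (Homo sapiens), read by scintillation counting and calcium flux, with a stated time of 90 min; a higher number here means a weaker inhibitor, a lower number a stronger inhibitor.
Compound 2, `Cc1ccc(S(=O)(=O)N2C=CNC(=O)[C@H]2CC(=O)N[C@@H]2CCCc3cc(CN(C)C)ccc32)cc1`, gives 1.25 nM in this assay.

Among these two measured compounds, compound 2 stands at the higher number, so it is the weaker inhibitor of the pair. Among the measured compounds shown here, the single measured step, a 28-fold higher number from compound 1 to compound 2 (1.44 log units; beyond the scatter), is large and well beyond the scatter, and it is the only comparison available.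

Compound 3, `Cc1ccc(S(=O)(=O)N2C=CNC(=O)[C@H]2CC(=O)N[C@@H]2CCCc3cc(CN4CCCC4)ccc32)cc1`, differs from compound 2 in one place: pyrrolidin-1-yl in place of dimethylamino on a saturated chain carbon bound to an aromatic carbon. The incoming group closes the open dimethylamino into a five-membered ring, whereas compound 1 carries piperidin-1-yl at the same place. The step of a 28-fold higher number from compound 1 to compound 2 (1.44 log units; beyond the scatter) is the one that bears on this change: opening the piperidin-1-yl ring to dimethylamino raised the number a great deal, so putting a ring back in its place is expected to lower it again. That ring is not the same one as in compound 1. The full return of a 28-fold higher number from compound 1 to compound 2 (1.44 log units; beyond the scatter) is not assumed. Compound 3 is therefore expected to give 0.15 nM in this assay, with a range from 0.04 nM to 0.6 nM. The expected step is an 8.3-fold lower number from compound 2 to compound 3 (0.92 log units; beyond the scatter), beyond the scatter.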

Compound 3, inhibition constant: 0.197 nM
Compound 3: middle estimate off by 1.3-fold (0.12 log units), on the low side; the measured number falls inside the stated range.
By their numbers in this assay, from the lowest: compound 1; then compound 3; then compound 2.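

At this position, on a saturated chain carbon bound to an aromatic carbon, closing dimethylamino into a ring recovers much of the ground lost with compound 2: in this assay there is a 6.3-fold lower number from compound 2 to compound 3 (0.80 log units; beyond the scatter), so a ring is favoured over the open group in two separate cases, compound 1 and compound 3. The new compound also shows that the two rings are not interchangeable, since pyrrolidin-1-yl does not match piperidin-1-yl and the comparison gives a 4.4-fold higher number from compound 1 to compound 3 (0.64 log units; beyond the scatter), a gap that lies beyond the usual scatter. Together, the three compounds form a ladder in which piperidin-1-yl gives the lowest number, pyrrolidin-1-yl the middle one and dimethylamino the highest, but nothing here explains why the ring or its size changes the result.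

The compounds shown leave open whether the number would keep falling with azepan-1-yl, or whether piperidin-1-yl is already the best ring size at this position. They also leave open how much depends on the ring nitrogen, which morpholin-4-yl or a plain cyclohexyl group in the same place could begin to test.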